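Furan-2-yl in place of 4-ethylphenyl on the shared core

The source may hold more compounds than are shown below. What is called first, only, known or untested is meant among the compounds shown, and "the series" means these compounds.

compound 1 `CC(Oc1ccc(CCC(=O)O)cc1)c1nc(-c2ccccc2)no1`: 2390 nM
compound 2 `CCc1ccc(-c2noc(COc3ccc(CCC(=O)O)cc3)n2)cc1`: 210 nM
compound 3 `O=C(O)CCc1ccc(OCc2nc(-c3ccc(C(F)(F)F)cc3)no2)cc1`: 610 nM

All numbers are from a functional assay on CHO cells for agonist activity at Free fatty acid receptor 1 (Homo sapiens), read by FLIPR and calcium flux, in the presence of a further agent that is not named here; a lower number here means that less compound is needed, a higher number that more compound is needed for the effect. Compound 2 stands at the lowest number of the three measured: compound 3 is nearest, compound 1 furthest, and both gaps are beyond the scatter. Compound 1 has a different linker and is not treated as a step here; its value simply stands well above that of compound 2. Going by the values given here, the one step measured at the aromatic carbon between the two ring nitrogens is a 2.9-fold higher number from compound 2 to compound 3 (0.46 log units; beyond the scatter), a modest loss.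

Compound 4 `O=C(O)CCc1ccc(OCc2nc(-c3ccco3)no2)cc1` differs from compound 2 by furan-2-yl in place of 4-ethylphenyl on an aromatic carbon. Among the compounds with values here, no measured step swaps the ring itself; the only nearby information is the ethyl to trifluoromethyl change, where compound 3 lost ground relative to compound 2 in this assay. Removing the ethyl and the six-membered ring altogether is a larger change than that, so a loss beyond the scatter is expected, of about a 3.8-fold higher number from compound 2 to compound 4 (0.58 log units; beyond the scatter). Compound 4 is therefore estimated at 800 nM, with a range of 300 nM to 2500 nM.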

Compound 4, half-maximal effective concentration: > 100000 nM
Compound 4 was reported as a limit; the forecaster's own chance of this, stated with the estimate: 5%; middle value at least 120-fold (2.09 log units) away from the limit.
By their numbers in this assay, from the lowest: compound 2; then compound 3; then compound 1. At a limit, above all of these: compound 4.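

In this assay, the aromatic carbon between two ring nitrogen atoms tolerates a change of substituent on the six-membered ring far better than a change of the ring itself. The step of a 2.9-fold higher number from compound 2 to compound 3 (0.46 log units; beyond the scatter) stays modest, whereas furan-2-yl in place of 4-ethylphenyl gives an at least 470-fold higher number from compound 2 to compound 4 (2.67 log units; beyond the scatter). The reading for compound 4 is a limit of the assay and not a number, so this step has no upper bound: the limit of > 100000 nM in this assay, at which 1 of the 4 values shown sits.

Ring size, the ring oxygen and the ethyl all change together in this step, and the compounds shown do not separate them. Thiophen-2-yl or 4-methylphenyl at this place on the shared core would bear on which of these changes goes with the loss.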